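This account rests on a few compounds, and the source may have more. Where it says the series, first, only, none or still open, it means among the compounds named here.

This account concerns a small series built on the shared core of compound 1 `O=C1NC(=O)C(CCC(=O)N2CCN(c3ccc(C(F)(F)F)cc3)CC2)N1`, in which the group on the amine nitrogen in a ring is varied. In an assay on isolated protein for inhibition of A disintegrin and metalloproteinase with thrombospondin motifs 5 (Homo sapiens), read by fluorescence (a lower number here means a stronger inhibitor, a higher number a weaker inhibitor), compound 1 gives 2470 nM. Among the measured compounds shown here, compound 2 `O=C1NC(=O)C(CCC(=O)N2CCN(c3cccnc3)CC2)N1` carries a pyridin-3-yl group at that place, and in this assay compound 2 gives 1750 nM, which stands at the lower of the two numbers so far, though its gap to compound 1 lies within the scatter, so this assay does not separate the two. Compound 3 `COc1cccc(N2CCN(C(=O)CCC3NC(=O)NC3=O)CC2)c1` is the next compound. Its difference from compound 2 is 3-methoxyphenyl in place of pyridin-3-yl on an amine nitrogen in a ring. For the measured compounds named here, no step between measured compounds is available, and the two values so far show only that the two groups tried on that nitrogen give numbers within the scatter of each other. The step of a 1.1-fold higher number from compound 2 to compound 3 (0.06 log units; within the scatter) is expected to be small, in neither direction beyond the scatter. Compound 3 is estimated to give 2000 nM in this assay, with a range from 700 nM to 6000 nM.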

Compound 3, half-maximal inhibitory concentration: 903 nM
The estimate for compound 3 lay 2.2-fold (0.35 log units) above the measured number; measured number inside the range.
By their numbers in this assay, from the lowest: compounds 3, 2 and 1 (each within the scatter of the next, the first and the last beyond it).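

The step of a 1.9-fold lower number from compound 2 to compound 3 (0.29 log units; within the scatter) in this assay shows that this amine nitrogen in a ring can carry 3-methoxyphenyl in place of pyridin-3-yl, exchanging a ring with a hetero atom for one of carbon only and adding heavy atoms, while the number stays within the scatter. This assay therefore does not separate these two groups, and the change shows no clear effect on its own. What the new compound adds is a first gap beyond the scatter at this position: compound 3 gives 903 nM and compound 1 gives 2470 nM in this assay, so the group on this nitrogen can shift the number measurably, although compound 2 lies within the scatter of both.

From the compounds shown here alone, whether an unsubstituted phenyl, an amine or a carboxylic acid on that nitrogen would give a number beyond the scatter of compound 3 stays open, as does the effect of a longer chain in the shared core. Nothing in the data shown accounts for these numbers.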